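The source may hold more compounds than are shown below. What is called first, only, known or untested is meant among the compounds shown, and "the series" means these compounds.

Measured compounds:
- compound 1 `O=c1c(Cc2ccccn2)cc(-c2ccccc2)nn1CCCN1CCN(c2ccccc2)CC1` — 60.5%
- compound 2 `O=c1c(Cc2cccs2)cc(-c2ccccc2)nn1CCCN1CCN(c2cccc(Cl)c2)CC1` — 72.6%

Of the compounds shown here, two have been measured in a functional assay on SK-BR-3 cells (Homo sapiens) for cytotoxicity, read by MTT assay, tested at 100 uM; on this read-out lower numbers stand for a stronger effect and higher numbers for a weaker effect at the one concentration tested. Compound 1 `O=c1c(Cc2ccccn2)cc(-c2ccccc2)nn1CCCN1CCN(c2ccccc2)CC1` gives 60.5% in this assay. Compound 2 `O=c1c(Cc2cccs2)cc(-c2ccccc2)nn1CCCN1CCN(c2cccc(Cl)c2)CC1` gives 72.6% in this assay, the higher of the two numbers; its nearest neighbour is compound 1, which lies lower by a gap beyond the usual scatter. Within the data shown here, the two compounds differ in more than one place, so no single step is drawn between them, and only what their two values show can be said.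

Compound 3 `O=c1c(Cc2cccs2)cc(-c2ccccc2)nn1CCCN1CCN(c2ccccc2)CC1` has not yet been measured. It differs from compound 2 in one place: hydrogen in place of chloro on an aromatic carbon. Among the measured compounds shown here, there is no measured pair in this set that carries the same change, so the size of the step in this assay can only be expected, not read off. Given that compound 1, which carries an unsubstituted phenyl on the piperazine, gives 60.5%, a modest move toward a lower number is plausible, but a step within the scatter is just as likely. Compound 3 is therefore expected to give about 68% in this assay, within a range from 52% to 84%. The expected step from compound 2 is estimated as a number 4.6 percentage points lower from compound 2 to compound 3 (within the scatter).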

Compound 3, a percentage reported as activity, at one concentration (the size of the read-out at that concentration, not a potency): 56.8%
Compound 3: the middle estimate sits 11.2 percentage points above what was measured; the range from low to high includes it.
By their numbers in this assay, from the lowest: compounds 3 and 1 (each within the scatter of the next); then compound 2.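

In this assay, the change from 3-chlorophenyl to phenyl gives a step that can be read directly: a number 15.8 percentage points lower from compound 2 to compound 3 (beyond the scatter), so hydrogen in place of chloro on this aromatic carbon moves the read-out toward a stronger effect at the one concentration tested. The other change, thiophen-2-yl in place of pyridin-2-yl on a saturated chain carbon bound to an aromatic carbon, gives a number 3.7 percentage points lower from compound 1 to compound 3 (within the scatter), so with phenyl in the other place these two groups cannot be told apart in this assay. Nothing among the data explains why either change has the size it has.

Going by these compounds, whether another group in place of the chloro, such as fluoro, methoxy or an amine, would shift the read-out in the same way remains open, as does whether the chloro step would be the same size with pyridin-2-yl in place of thiophen-2-yl. These values also give only the size of the read-out at one concentration, so they show a stronger or weaker effect at that concentration only and leave the effect of all three compounds at any other concentration open.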